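This account rests on a few compounds, and the source may have more. Where it says the series, first, only, none or still open, it means among the compounds named here.

Measured compounds:
Compound 1 `COc1cc(-c2nn(-c3cccc(NC(=O)Nc4ccc(Cl)c(Cl)c4)c3)cc2-c2ccncc2)ccc1Cl`; in a functional assay on K562 cells (Homo sapiens) for inhibition, read by sulforhodamine B assay, with a stated time of 48 h (a lower number here means that less compound is tolerated, a higher number that more compound is tolerated), compound 1 gives > 50000 nM, which is a limit of the assay and not a number.
Compound 2 `O=C(Nc1cccc(-n2cc(-c3ccncc3)c(-c3ccc(Cl)c(O)c3)n2)c1)Nc1ccc(Cl)c(Cl)c1`; in this assay compound 2 gives > 32500 nM, again a limit.
Compound 3 `COc1cc(-c2nn(-c3cccc(NC(=O)Nc4ccc(Cl)c(C(F)(F)F)c4)c3)cc2-c2ccncc2)ccc1Cl`; in this assay compound 3 gives > 32500 nM, also a limit.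

Compound 2 differs from compound 1 by hydrogen in place of methyl on an oxygen on an aromatic ring. Because both values are limits, the step that the two limits leave unreadable from compound 1 to compound 2 cannot be read. Compound 3 differs from compound 1 by trifluoromethyl in place of chloro on an aromatic carbon, and here too the step that the two limits leave unreadable from compound 1 to compound 3 is left unreadable, the pair sitting at the limit of > 50000 nM in this assay, at which 1 of the 3 values shown sits, and (the limit of > 32500 nM in this assay, at which 2 of the 3 values shown sit).

Compound 4 `O=C(Nc1cccc(-n2cc(-c3ccncc3)c(-c3ccc(Cl)c(O)c3)n2)c1)Nc1ccc(Cl)c(C(F)(F)F)c1` has not been measured in this assay. It differs from compound 3 by hydrogen in place of methyl on an oxygen on an aromatic ring. The place of this change is described in the same words as for the change from compound 1 to compound 2, so it is the same change made on a second core. Its size from compound 1 to compound 2 is not readable, since both of those values are limits.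

For compound 4 the step that the limit leaves unreadable from compound 3 to compound 4 is therefore expected to be small or unreadable, because compound 3 itself sits at the limit of > 32500 nM in this assay, at which 2 of the 3 values shown sit, and the same change left compound 2 at the limit of > 32500 nM in this assay, at which 2 of the 3 values shown sit, as well. Compound 4 is estimated at 50000 nM in this assay, with a range from 20000 nM to 120000 nM, and most likely the assay will again report only a limit.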

Compound 4, concentration lethal to 50% of the cells: > 32500 nM
Compound 4 ended at the assay's limit; the forecaster's own chance of this, stated with the estimate: 85%; the middle value lies beyond the limit too.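

In this assay compound 4 gives > 32500 nM, which is a limit of the assay and not a number. The steps to compound 4 from compound 3 and from compound 2 cannot be read, as all three values are limits. The compounds shown leave open what size, if any, the change from methoxy to hydroxy or from chloro to trifluoromethyl has on this read-out.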